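Replacing the benzyl group on the ring amine of compound 3

The compounds below may be only part of what the source reports. "The series", "measured", "known", "first", "only" and "open" are said of these compounds alone.

Compound 1: `NC(=O)c1c(NC(=O)c2ccccc2Cl)sc2c1CCNC2` — 18600 nM
Compound 2: `NC(=O)c1c(NC(=O)c2ccccc2Cl)sc2c1CCN(Cc1ccc([N+](=O)[O-])cc1)C2` — 11400 nM
Compound 3: `NC(=O)c1c(NC(=O)c2ccccc2Cl)sc2c1CCN(Cc1cc(Cl)cc(Cl)c1)C2` — 15800 nM

In a functional assay on HL-60 cells (Homo sapiens) for antiproliferative activity, with a stated time of 24 h (a higher number here means a weaker inhibitor, a lower number a stronger inhibitor), compound 3 gives 15800 nM. Its position among the three measured compounds is set by a 1.2-fold lower number from compound 1 to compound 3 (0.07 log units; within the scatter) and by a 1.4-fold higher number from compound 2 to compound 3 (0.14 log units; within the scatter), so all three numbers sit together.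

Compound 4, `COc1ccccc1NC(=S)N1CCc2c(sc(NC(=O)c3ccccc3Cl)c2C(N)=O)C1`, differs from compound 3 in one place: a group of 11 heavy atoms (8 carbon, 1 nitrogen, 1 oxygen, 1 sulfur; one six-membered aromatic ring of carbon only) in place of a group of 9 heavy atoms (7 carbon, 2 chlorine; one six-membered aromatic ring of carbon only), on an amine nitrogen in a ring. Within the data shown here, the steps that bear on this are a 1.6-fold lower number from compound 1 to compound 2 (0.21 log units; within the scatter), a 1.2-fold lower number from compound 1 to compound 3 (0.07 log units; within the scatter) and a 1.4-fold higher number from compound 2 to compound 3 (0.14 log units; within the scatter): every exchange at that amine nitrogen so far has stayed within the scatter. The step from compound 3 is therefore expected to be a 1.1-fold lower number from compound 3 to compound 4 (0.02 log units; within the scatter), with no direction claimed. Compound 4 is estimated at 15000 nM, in a range from 6000 nM to 40000 nM.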

Compound 4, half-maximal inhibitory concentration: 40900 nM
Compound 4: the middle estimate sits 2.7-fold (0.44 log units) below what was measured, outside the stated range (above it).
By their numbers in this assay, from the lowest: compounds 2, 3 and 1 (each within the scatter of the next); then compound 4.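

Among these compounds, this is the first exchange on the amine nitrogen in a ring to go beyond the scatter in this assay, with the group of 11 heavy atoms set against either benzyl group (a 2.6-fold higher number from compound 3 to compound 4 (0.41 log units; beyond the scatter); a 3.6-fold higher number from compound 2 to compound 4 (0.55 log units; beyond the scatter)). The same group also gives a weaker inhibitor than the hydrogen atom (a 2.2-fold higher number from compound 1 to compound 4 (0.34 log units; beyond the scatter)), whereas both benzyl groups stayed within the scatter of it. Nothing measured here accounts for the change.

As far as these compounds go, whether the change follows the sulfur-containing link or the methoxyphenyl ring stays open. So does how a urea with oxygen in place of the sulfur, or a plain acetyl group, would behave on this nitrogen.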